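Compound 3 to compound 4: a larger amide group

This account rests on a few compounds, and the source may have more. Where it says the series, first, only, none or still open, it means among the compounds named here.

Going by the values given here, in a functional assay on the whole organism with Mus musculus as the target (on this read-out higher numbers stand for an effect only at larger amounts of compound and lower numbers for an effect already at smaller amounts), compound 1 `O=C(/C=C/c1cccc(C(F)(F)F)c1)NCCO` gives 78.6 mg/kg, the only true number so far. For compound 2 `CCCCN1C(=O)CCC1(O)c1cccc(C(F)(F)F)c1` the reading is a limit, > 200 mg/kg. For compound 3 `CN(C)C(=O)CCC(=O)c1cccc(C(F)(F)F)c1` the reading is also a limit, > 50 mg/kg. On these data alone, compound 3 therefore has no exact place in this assay, and its order relative to compound 1 stays open.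

Compound 4 `CN1CCN(C(=O)CCC(=O)c2cccc(C(F)(F)F)c2)CC1` keeps the rest of compound 3 and differs in one place: 4-methylpiperazin-1-yl in place of dimethylamino on a carbonyl carbon. This puts 4-methylpiperazin-1-yl in place of dimethylamino on a carbonyl carbon.

Among the compounds with values here, no measured pair isolates this change, so the expectation is loose. The expected step that the limit leaves unreadable from compound 3 to compound 4 is small, with no direction expected beyond the scatter. The expectation is anchored on compound 1 at 78.6 mg/kg. For compound 4, a further limit reading is quite possible. For compound 4 the estimated value is 80 mg/kg, with an expected range of 35 mg/kg to 250 mg/kg.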

Compound 4, dose for half-maximal effect: > 50 mg/kg
Compound 4: no number, only a limit; the forecaster's own chance of this, stated with the estimate: 50%; the middle value does not contradict the limit.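

Compound 3 and compound 4 both give only limits in this assay, so no step can be read between them. The compounds shown leave open whether 4-methylpiperazin-1-yl in place of dimethylamino on a carbonyl carbon shifts the read-out at all, and in which direction.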